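Tetrazole for Carboxy on a Fused Core: Expected Dose

This account rests on a few compounds, and the source may have more. Where it says the series, first, only, none or still open, it means among the compounds named here.

The study compares four compounds on a shared core and follows one change. Compound 1 `O=C(O)c1cnc2ccc(C3CCCCC3)cc2c1` carries a cyclohexyl group and a carboxy group, compound 2 `O=C(O)c1cnc2cc(C(F)(F)F)ccc2c1` carries a trifluoromethyl group and a carboxy group, and compound 3 `FC(F)(F)c1ccc2cc(-c3nn[nH]n3)cnc2c1` carries the trifluoromethyl group together with a 2H-tetrazol-5-yl. The difference between the two cores of compound 1 and compound 2 is not broken down here.

In a functional assay on the whole organism (strain Sprague-Dawley) for inhibition, with Rattus norvegicus as the target (on this read-out higher numbers stand for an effect only at larger amounts of compound and lower numbers for an effect already at smaller amounts), compound 1 reaches only a limit of > 25 mg/kg. Compound 2 likewise reaches only a limit, > 25 mg/kg. Compound 3 gives a limit as well, < 10 mg/kg. The change 2H-tetrazol-5-yl in place of carboxy on an aromatic carbon thus yields an at least 2.5-fold lower number from compound 2 to compound 3 (0.39 log units; beyond the scatter); its size is known only as a bound because the limit of > 25 mg/kg in this assay, at which 2 of the 3 values shown sit, and the limit of < 10 mg/kg in this assay, at which 1 of the 3 values shown sits, are the two limits that frame it.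

Compound 4 `c1nc2ccc(C3CCCCC3)cc2cc1-c1nn[nH]n1` is not yet measured. It arises from compound 1 by 2H-tetrazol-5-yl in place of carboxy on an aromatic carbon, the same change, at a place described in the same words as for compound 2 and compound 3. For the measured compounds named here, its step is expected to be an at least 2.5-fold lower number from compound 1 to compound 4 (0.39 log units; beyond the scatter), set beside an at least 2.5-fold lower number from compound 2 to compound 3 (0.39 log units; beyond the scatter) as the one measured instance of this change. Compound 4 is therefore estimated at 10 mg/kg in this assay, most likely between 3 mg/kg and 30 mg/kg, with a real chance that only a limit is reported.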

Compound 4, minimum effective dose: 5 mg/kg
The estimate for compound 4 lay 2.0-fold (0.30 log units) above the measured number; the measured number falls inside the stated range.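

In this assay, putting 2H-tetrazol-5-yl in place of carboxy on the core that carries cyclohexyl gives an at least 5.0-fold lower number from compound 1 to compound 4 (0.69 log units; beyond the scatter), so the direction seen on the core that carries trifluoromethyl recurs on a second core. Set side by side, the two instances read as follows: the same change on two cores in this assay, an at least 2.5-fold lower number (0.39 log units; beyond the scatter) from compound 2 to compound 3 and an at least 5.0-fold lower number (0.69 log units; beyond the scatter) from compound 1 to compound 4; the limit leaves it open whether they differ This shows that the change lowered the number on both cores shown, but it does not give the true size of either step or show that the change would carry to any further core, and the carboxy compounds on both cores stand only at a limit of the assay: the limit of > 25 mg/kg in this assay, at which 2 of the 4 values shown sit.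

The compounds shown leave open whether the same step would appear on a core carrying an amine, a methoxy group or a longer chain where cyclohexyl and trifluoromethyl stand now. They also leave open whether an amide, a nitrile or a sulfonic acid on the same aromatic carbon, two atoms from the ring nitrogen, would behave like 2H-tetrazol-5-yl or like carboxy.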